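From phenoxy to sulfamoyl in a growth inhibition test

The source may report more compounds than this note shows. Statements on the series, on what has been measured and on what is new or still open speak of the compounds shown alone.

Two compounds have been measured in a functional assay on MDA-MB-231 cells (Homo sapiens) for inhibition, read by MTT assay, with a stated time of 48 h; a higher number here means a weaker inhibitor of growth, a lower number a stronger inhibitor of growth
- Compound 1 `Cc1cccc(Nc2ncnc3ccc(NC(=S)NCc4ccccc4)cc23)c1` gives 19500 nM
- Compound 2 `S=C(NCc1ccccc1)Nc1ccc2ncnc(Nc3ccc(Oc4ccccc4)cc3)c2c1` gives 6800 nM

Compound 2 has the lower number of the two, and its gap to compound 1 lies beyond the usual scatter. Compound 3 `NS(=O)(=O)c1ccc(Nc2ncnc3ccc(NC(=S)NCc4ccccc4)cc23)cc1` carries sulfamoyl in place of phenoxy on an aromatic carbon. Going by the values given here, no measured pair shows this change directly, so the forecast is loose. Among the compounds with values here, the only measured compound without phenoxy, compound 1, gives 19500 nM and so points toward a higher number. A rise in this assay is therefore expected, estimated as a 2.1-fold higher number from compound 2 to compound 3 (0.31 log units; beyond the scatter) in size. Compound 3 is expected at 14000 nM with 5000 nM to 40000 nM as the estimated range.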

Compound 3, concentration for 50% growth inhibition: > 30000 nM
Compound 3 gave a limit, no number; the forecaster's own chance of this, stated with the estimate: 15%; middle value at least 2.1-fold (0.33 log units) from the limit.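

In this assay, compound 3 gave a limit of the assay rather than a number: the limit of > 30000 nM in this assay, at which 1 of the 3 values shown sits. Putting sulfamoyl in place of phenoxy at this position, para to a large group, gives an at least 4.4-fold higher number from compound 2 to compound 3 (0.64 log units; beyond the scatter), the first direct view of this change, and the real gap could be larger. The other step, an at least 1.5-fold higher number from compound 1 to compound 3 (0.18 log units; that floor lies within the scatter), does not yet settle how compound 3 stands against compound 1. Still open, from the compounds shown here alone, is where an amine or a carboxylic acid at this position would fall relative to compound 2.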